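Methyl Groups on the Benzothiazole of Compound 3

The source may hold more compounds than are shown below. What is called first, only, known or untested is meant among the compounds shown, and "the series" means these compounds.

Three compounds sharing one core were measured in a functional assay on MCF7 cells (Homo sapiens) for cytotoxicity, read by MTT assay, with a stated time of 48 h; on this read-out lower numbers stand for stronger inhibition and higher numbers for weaker inhibition. Compound 1 `COc1ccc(-c2cc(C(=O)Nc3nc4ccc(Cl)cc4s3)nc3cc(-c4ccccc4)nn23)cc1OC` gives 6910 nM, compound 2 `COc1ccc2nc(NC(=O)c3cc(-c4ccc(OC)c(OC)c4)n4nc(-c5ccccc5)cc4n3)sc2c1` gives 18700 nM, and compound 3 `COc1ccc(-c2cc(C(=O)Nc3nc4ccccc4s3)nc3cc(-c4ccccc4)nn23)cc1OC` gives 14700 nM, the second highest of the three numbers; a 1.3-fold lower number from compound 2 to compound 3 (0.10 log units; within the scatter) lies within the scatter, while a 2.1-fold higher number from compound 1 to compound 3 (0.33 log units; beyond the scatter) lies beyond it. Compound 4 `COc1ccc(-c2cc(C(=O)Nc3nc4cc(C)c(C)cc4s3)nc3cc(-c4ccccc4)nn23)cc1OC` differs from compound 3 in one place: 5,6-dimethyl-1,3-benzothiazol-2-yl in place of 1,3-benzothiazol-2-yl on an amide-type nitrogen. The two measured steps, a 2.1-fold higher number from compound 1 to compound 3 (0.33 log units; beyond the scatter) and a 1.3-fold lower number from compound 2 to compound 3 (0.10 log units; within the scatter), show that changing a substituent on this ring moves the number only modestly. Compound 4 is therefore expected to give a modestly lower number, a 1.6-fold lower number from compound 3 to compound 4 (0.21 log units; within the scatter), with an estimate of 9000 nM and a range from 4000 nM to 20000 nM.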

Compound 4, half-maximal inhibitory concentration: 2510 nM
The estimate for compound 4 lay 3.6-fold (0.55 log units) above the measured number; the whole stated range lies above it.
By their numbers in this assay, from the lowest: compound 4; then compound 1; then compounds 3 and 2 (each within the scatter of the next).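

In this assay, the 5,6-dimethyl-1,3-benzothiazol-2-yl group gives a larger shift than the earlier changes on this ring, with a 5.9-fold lower number from compound 3 to compound 4 (0.77 log units; beyond the scatter). It also gives lower numbers than the methoxy and chloro versions, with a 7.5-fold lower number from compound 2 to compound 4 (0.87 log units; beyond the scatter) and a 2.8-fold lower number from compound 1 to compound 4 (0.44 log units; beyond the scatter), so this group on the amide-type nitrogen has more influence on the number than the first three compounds suggested. No available evidence explains this drop.

From the compounds shown here alone, it remains open whether a single methyl group would give the same drop. Going by these compounds, the effect of an ethyl group or an amine on this ring also remains open.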